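This account rests on a few compounds, and the source may have more. Where it says the series, first, only, none or still open, it means among the compounds named here.

Measured in an ADME assay on a cell-free system (plasma, Homo sapiens) for metabolic stability, read by LC-MS; a higher number here means that the compound lasts longer, a lower number that the compound disappears faster:
- Compound 1 (`CCCCOC(=O)c1cccc(-c2cc(C(=O)Nc3ccncc3)ccc2CN)c1`): 0.367 h
- Compound 2 (`NCc1ccc(C(=O)Nc2ccncc2F)cc1-c1cccc(C(=O)OCC2CC2)c1`): 0.3 h
- Compound 3 (`NCc1ccc(C(=O)Nc2ccncc2)cc1-c1cccc(C(=O)OCC2CCCC2)c1`): 0.517 h

Compound 2, at 0.3 h, lies within the scatter of both other compounds. Compound 4 (`NCc1ccc(C(=O)Nc2ccncc2F)cc1-c1cccc(C(=O)O)c1`) differs from it as follows: hydrogen in place of cyclopropylmethyl on an oxygen next to a carbonyl group. This turns cyclopropylmethoxycarbonyl into carboxy. Within the data shown here, the only measured step, a 1.4-fold higher number from compound 1 to compound 3 (0.15 log units; within the scatter), exchanges one group on that oxygen for another and stays within the scatter, so it cannot size a complete removal. Among the measured compounds shown here, no measured compound lacks such a group, which leaves this expectation uncertain. All the half-lives so far come from compounds that keep one, such as compound 3 at 0.517 h, so a large rise is expected. The expected change is a 67-fold higher number from compound 2 to compound 4 (1.82 log units; beyond the scatter). Compound 4 is estimated at 20 h, within an expected range of 5 h to 50 h.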

Compound 4, half-life: > 2 h
Compound 4 was reported as a limit; the forecaster's own chance of this, stated with the estimate: 60%; the middle value is on the limit's open side.
By their numbers in this assay, from the lowest: compounds 2, 1 and 3 (each within the scatter of the next). At a limit, above all of these: compound 4.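

Replacing cyclopropylmethyl with hydrogen on an oxygen next to a carbonyl group turns the ester into a carboxy group and gives an at least 6.6-fold higher number from compound 2 to compound 4 (0.82 log units; beyond the scatter). Exchanging one group on that oxygen for another stayed within the scatter, at a 1.4-fold higher number from compound 1 to compound 3 (0.15 log units; within the scatter), so only complete removal has produced a clear step here. Compound 4 is reported in this assay as a limit, not a number: the limit of > 2 h in this assay, at which 1 of the 4 values shown sits.

As far as these compounds go, how far the true half-life of compound 4 lies past that limit remains open. So does whether a methyl group on that oxygen, or a primary amide in place of the carboxy group, would give a similar step.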